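The source may report more compounds than this note shows. Statements on the series, on what has been measured and on what is new or still open speak of the compounds shown alone.

In an ADME assay on MDCK cells (Canis lupus familiaris) for cytotoxicity, read by MTT assay, with a stated time of 48 h (on this read-out lower numbers stand for higher toxicity in this test and higher numbers for lower toxicity in this test), compound 1 `ClC1=C(Cn2cc(-c3ccc(Cl)c(Cl)c3)nn2)CCc2nc(-c3cccs3)ccc21`, bearing 3,4-dichlorophenyl, reads > 300 ug/mL, which is a limit of the assay. Compound 2 `FC(F)(F)Oc1ccc(-c2cn(CC3=C(Cl)c4ccc(-c5cccs5)nc4CC3)nn2)cc1`, bearing 4-(trifluoromethoxy)phenyl, reads > 300 ug/mL, also a limit. Going by the values given here, compound 3 `CCCCCc1cn(CC2=C(Cl)c3ccc(-c4cccs4)nc3CC2)nn1`, bearing pentyl, gives 50 ug/mL, the only actual number of the three. Compound 4 `ClC1=C(Cn2cc(C3CC3)nn2)CCc2nc(-c3cccs3)ccc21` has cyclopropyl in place of pentyl on the same aromatic carbon: cyclopropyl in place of pentyl on an aromatic carbon. Two measured steps changed this same group, an at least 6.0-fold lower number from compound 1 to compound 3 (0.77 log units; beyond the scatter) and an at least 6.0-fold lower number from compound 2 to compound 3 (0.77 log units; beyond the scatter), and both lie beyond the scatter. Neither involves cyclopropyl, so they guide the expectation only loosely, but a modest rise in this assay seems likely. The expected step is a 2.6-fold higher number from compound 3 to compound 4 (0.41 log units; beyond the scatter). The estimated value for compound 4 is 130 ug/mL, with an expected range of 50 ug/mL to 300 ug/mL.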

Compound 4, half-maximal cytotoxic concentration: > 300 ug/mL
Compound 4: a limit, no number; the forecaster's own chance of this, stated with the estimate: 30%; at least 2.3-fold (0.36 log units) between middle value and limit.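

In this assay, cyclopropyl in place of pentyl on this aromatic carbon gives an at least 6.0-fold higher number from compound 3 to compound 4 (0.77 log units; beyond the scatter), so a low reading here does not extend to every non-aromatic group at this position. Going by these compounds alone, compound 3 now stands alone as the only compound with an actual number, while the others rest at a limit: the limit of > 300 ug/mL in this assay, at which 3 of the 4 values shown sit. The steps from compound 1 and from compound 2 to compound 4 join limit to limit and cannot be read. From the compounds shown here alone, how far above that limit those three compounds lie remains open. So does whether a butyl chain, a longer chain or an amine here would read like pentyl.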